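Aryl swaps on the shared core: microsomal clearance notes

This account rests on a few compounds, and the source may have more. Where it says the series, first, only, none or still open, it means among the compounds named here.

- Compound 1 `CC(C)n1cc(-c2cc(C(O)(C(F)(F)F)C(F)(F)F)cnc2N2CCN(S(=O)(=O)c3ccc(N)nc3)CC2)cn1` gives 198 mL.min-1.g-1
- Compound 2 `Cc1csc(-c2cc(C(O)(C(F)(F)F)C(F)(F)F)cnc2N2CCN(S(=O)(=O)c3ccc(N)nc3)CC2)c1` gives 399 mL.min-1.g-1

Both were read in an ADME assay (liver) for metabolic stability, with Liver microsome (Rattus norvegicus) as the target, using microsomes and NADPH, with a stated time of 30 min, tested at 1 uM (on this read-out lower numbers stand for slow clearance and higher numbers for fast clearance), and compound 2 stands within the scatter of compound 1 (a 2.0-fold higher number from compound 1 to compound 2 (0.30 log units; within the scatter)). Compound 3 `CS(=O)(=O)c1ccc(-c2cc(C(O)(C(F)(F)F)C(F)(F)F)cnc2N2CCN(S(=O)(=O)c3ccc(N)nc3)CC2)cc1` carries 4-(methylsulfonyl)phenyl in place of 4-methylthiophen-2-yl on the same aromatic carbon (4-(methylsulfonyl)phenyl in place of 4-methylthiophen-2-yl on an aromatic carbon). Going by the values given here, the only measured step at this place is the one above, which stays within the scatter, and no measured compound carries a sulfonyl group on this aryl position. No shift beyond the scatter is therefore expected in this assay, and the expected step is small and downward (a 1.8-fold lower number from compound 2 to compound 3 (0.26 log units; within the scatter)). Compound 3 is estimated at 220 mL.min-1.g-1 (90 mL.min-1.g-1 to 480 mL.min-1.g-1).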

Compound 3, intrinsic clearance in microsomes: 103 mL.min-1.g-1
For compound 3 the middle estimate is 2.1-fold (0.33 log units) above the measured one; low and high end bracket the measured number.
By their numbers in this assay, from the lowest: compounds 3, 1 and 2 (each within the scatter of the next, the first and the last beyond it).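

In this assay this aromatic carbon now shows a step beyond the scatter (a 3.9-fold lower number from compound 2 to compound 3 (0.59 log units; beyond the scatter)), with 4-(methylsulfonyl)phenyl in place of 4-methylthiophen-2-yl, so the aryl swap here can move the clearance read-out. Against 1-isopropyl-1H-pyrazol-4-yl, the same group stays within the scatter (a 1.9-fold lower number from compound 1 to compound 3 (0.28 log units; within the scatter)). Nothing available bears on what lies behind the step.

As far as these compounds go, whether the step follows the methylsulfonyl group or the six-membered ring stays open. So does the read-out with an amine or a carboxylic acid on the phenyl ring in place of the methylsulfonyl group.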